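The source may hold more compounds than are shown below. What is called first, only, known or untested is meant among the compounds shown, and "the series" means these compounds.

In a functional assay on HepG2 cells (Homo sapiens) for antiproliferative activity, read by MTT assay, with a stated time of 24 h (on this read-out lower numbers stand for stronger inhibition and higher numbers for weaker inhibition), compound 1 `COC(=O)c1scc(-c2ccc(NC(=O)c3cccc(C(F)(F)F)c3)cc2)c1OC` gives 32500 nM and compound 2 `COC(=O)c1scc(-c2ccc(NC(=O)c3ccc(F)c(Cl)n3)cc2)c1OC` gives 10300 nM. Compound 2 therefore holds the lower of the two numbers and shows the stronger inhibition so far. Compound 3 `COC(=O)c1scc(-c2ccc(NC(=O)c3cccc(I)c3)cc2)c1OC` keeps the shared core but differs from compound 2 in one place: 3-iodophenyl in place of 6-chloro-5-fluoropyridin-2-yl on a carbonyl carbon. In words, 3-iodophenyl stands in place of 6-chloro-5-fluoropyridin-2-yl on a carbonyl carbon. Within the data shown here, only one measured step bears on this change: a 3.2-fold lower number from compound 1 to compound 2 (0.50 log units; beyond the scatter). That modest step brought in the same pyridine group that compound 3 now gives up. Compound 3 again carries a substituted phenyl, like compound 1 at 32500 nM, so part of that drop is expected to reverse, although iodine has not yet been tested here. The expected change is a 2.1-fold higher number from compound 2 to compound 3 (0.33 log units; beyond the scatter). The estimate for compound 3 is 22000 nM, with an expected range from 8000 nM to 60000 nM.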

Compound 3, half-maximal inhibitory concentration: 16500 nM
For compound 3 the middle estimate is 1.3-fold (0.12 log units) above the measured one; the range from low to high includes it.
By their numbers in this assay, from the lowest: compounds 2, 3 and 1 (each within the scatter of the next, the first and the last beyond it).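

In this assay the change reads as a 1.6-fold higher number from compound 2 to compound 3 (0.20 log units; within the scatter) and so a ring of carbon only bearing iodine cannot be told apart from 6-chloro-5-fluoropyridin-2-yl on this carbonyl carbon, which means the ring nitrogen of the pyridine group is not shown to be required. The second comparison reads as a 2.0-fold lower number from compound 1 to compound 3 (0.29 log units; within the scatter) and so iodo and trifluoromethyl on this aromatic carbon cannot be told apart either, leaving compound 3 within the scatter of both compound 1 and compound 2, although those two lie beyond the scatter of each other. No measurement at hand explains these numbers.

On these data alone, it remains open whether an amine or a carboxylic acid in place of the iodo group would change the number beyond the scatter. The same question stands for a saturated ring such as cyclohexyl on the carbonyl carbon.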